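The source may hold more compounds than are shown below. What is called first, only, known or untested is meant among the compounds shown, and "the series" means these compounds.

Of the compounds shown here, three built on one shared core have been measured in an assay on isolated protein for inhibition of protein deacetylase HDAC6 (Homo sapiens), read by fluorescence, with a stated time of 15 min; a higher number here means a weaker inhibitor, a lower number a stronger inhibitor. Compound 1 `O=C(NO)c1ccc(/C=C/c2ccnc(-c3cc(F)ccc3O)c2)cc1` gives 130 nM. Compound 2 `O=C(NO)c1ccc(/C=C/c2ccnc(-c3cccc(CO)c3)c2)cc1` gives 34 nM, and the step of a 3.8-fold lower number from compound 1 to compound 2 (0.58 log units; beyond the scatter) lies beyond the scatter. Compound 3 `O=C(NO)c1ccc(/C=C/c2ccnc(-c3cccnc3)c2)cc1` gives 14 nM, the lowest of the three numbers, with the steps of a 2.4-fold lower number from compound 2 to compound 3 (0.39 log units; beyond the scatter) and a 9.3-fold lower number from compound 1 to compound 3 (0.97 log units; beyond the scatter) both beyond the scatter. Compound 4 `Cc1ccc(-c2cc(/C=C/c3ccc(C(=O)NO)cc3)ccn2)cc1` has not yet been measured. It differs from compound 3 in one place: 4-methylphenyl in place of pyridin-3-yl on an aromatic carbon. Within the data shown here, the steps that bear on this change are the two in which pyridin-3-yl entered, a 2.4-fold lower number from compound 2 to compound 3 (0.39 log units; beyond the scatter) and a 9.3-fold lower number from compound 1 to compound 3 (0.97 log units; beyond the scatter), each of which lowered the number. Taking pyridin-3-yl out again in favour of a six-membered ring of carbon only is expected to move the number upward by roughly the size of the smaller of those steps, giving an expected step of a 2.9-fold higher number from compound 3 to compound 4 (0.46 log units; beyond the scatter). Compound 4 is thus estimated at 40 nM, with a range from 15 nM to 110 nM.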

Compound 4, half-maximal inhibitory concentration: 150 nM
Estimate against measurement, compound 4: 3.8-fold (0.57 log units) below; the whole stated range lies below it.
By their numbers in this assay, from the lowest: compound 3; then compound 2; then compounds 1 and 4 (each within the scatter of the next).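

In this assay the position next to the ring nitrogen proves far from indifferent to which ring it carries, as putting 4-methylphenyl in place of pyridin-3-yl gives a large loss (an 11-fold higher number from compound 3 to compound 4 (1.03 log units; beyond the scatter)). A ring of carbon only does not by itself fix the number: 4-methylphenyl also falls behind 3-(hydroxymethyl)phenyl (a 4.4-fold higher number from compound 2 to compound 4 (0.64 log units; beyond the scatter)), while it cannot be told apart from 5-fluoro-2-hydroxyphenyl (a 1.2-fold higher number from compound 1 to compound 4 (0.06 log units; within the scatter)). Nothing available explains why these rings differ. From the compounds shown here alone, the step to compound 4 removes the ring nitrogen and adds the methyl together, so the share of each stays open, and a plain phenyl group would be needed to divide them. Also open, going by these compounds, is how an amine or a carboxylic acid on this ring would compare with pyridin-3-yl.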